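The source may report more compounds than this note shows. Statements on the series, on what has been measured and on what is new or still open speak of the compounds shown alone.

Working notes on the series. In a functional assay on MCF7 cells (Homo sapiens) for inhibition (on this read-out lower numbers stand for stronger inhibition and higher numbers for weaker inhibition), compound 1 (`CCCCCCCC[C@@]1(C)SC(=O)C=C1OC`) reads > 50 ug/mL, which is a limit of the assay and not a number. Going by the values given here, compound 2 (`CCCCCC[C@@]1(C)SC(=O)C=C1OCC(=O)OCC`) gives 14.2 ug/mL, the only actual number so far, so its standing cannot yet be set against a second measured value. Compound 3 (`CCCCCCCC[C@@]1(C)SC(=O)C=C1OCC(=O)OCC`) is the next to be read, and it differs from compound 2 in one place: ethyl in place of hydrogen on a saturated chain carbon, six bonds along the chain from a saturated ring carbon. Among the compounds with values here, no measured pair isolates this change, so its size has no direct precedent. With compound 2 at 14.2 ug/mL as the sole anchor, no step beyond the usual scatter is expected in this assay, and no direction is favoured. The estimated step is a 1.3-fold higher number from compound 2 to compound 3 (0.10 log units; within the scatter). For compound 3 the estimated value is 18 ug/mL, with an expected range of 7 ug/mL to 45 ug/mL.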

Compound 3, half-maximal inhibitory concentration: 10.8 ug/mL
For compound 3 the middle estimate is 1.7-fold (0.22 log units) above the measured one; the range from low to high includes it.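

In this assay, ethyl in place of hydrogen on a saturated chain carbon, six bonds along the chain from a saturated ring carbon, gives a 1.3-fold lower number from compound 2 to compound 3 (0.12 log units; within the scatter), so this position takes the longer chain without a change beyond the scatter. Ethoxycarbonyl in place of hydrogen on a saturated chain carbon bound to an oxygen on an unsaturated carbon gives an at least 4.6-fold lower number from compound 1 to compound 3 (0.66 log units; beyond the scatter), and of the two steps shown, only this one lies beyond the scatter. The reading for compound 1 is a limit of the assay and not a number, so the size of this step is only a bound: the limit of > 50 ug/mL in this assay, at which 1 of the 3 values shown sits.

The ethoxycarbonyl step is read on a single chain length. On these data alone, whether a still longer chain keeps the read-out stays open, as does whether a carboxylic acid or an amide in place of the ethyl ester does so.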